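The source may hold more compounds than are shown below. What is called first, only, known or untested is meant among the compounds shown, and "the series" means these compounds.

Compound 1 `CCOC(=O)c1nn(-c2ccc(Cl)cc2)c(-c2ccc(OC)cc2OC)c1C` and compound 2 `CCOC(=O)c1nn(-c2ccc(Cl)cc2)c(-c2ccc(OC)cc2OC)c1-c1ccccc1` share a core and were both tested in a functional assay on the whole organism (strain albino) for inhibition, with Rattus norvegicus as the target, read by paw edema, with stated times of 30 min and 4 h, at a dose of 25 mg/kg by the intraperitoneal route; on this read-out lower numbers stand for less inhibition and higher numbers for more inhibition at the one dose given (going by the name of the read-out). In this assay compound 1 gives 2.38%, the lowest of the two numbers, while compound 2 gives 15.4%. Among the measured compounds shown here, the one measured step, a number 13 percentage points higher from compound 1 to compound 2 (beyond the scatter), arises from a phenyl in place of methyl on an aromatic carbon. Compound 3 `COc1ccc(-c2c(C)c(C(=O)O)nn2-c2ccc(Cl)cc2)c(OC)c1` has not yet been measured in this assay. It differs from compound 1 as follows: hydrogen in place of ethyl on an oxygen next to a carbonyl group. For the measured compounds named here, no measured step touches this oxygen next to a carbonyl group; the only known step concerns a different part of the molecule, so it gives no direct guidance on the size or direction of the change from an ethyl to a hydrogen there. With nothing to point either way, the step of a number 0.6 percentage points higher from compound 1 to compound 3 (within the scatter) is expected to stay within the scatter of repeated measurements. Compound 3 is therefore estimated to give 3% in this assay, with a range from -6% to 14%.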

Compound 3, a percentage reported as inhibition, in the whole organism at one dose (the size of the read-out at that dose, not a potency): 22.7%
Estimate against measurement, compound 3: 19.7 percentage points below; measured number above the stated range.
By their numbers in this assay, from the lowest: compound 1; then compounds 2 and 3 (each within the scatter of the next).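

In this assay, the step of a number 20.3 percentage points higher from compound 1 to compound 3 (beyond the scatter) comes from hydrogen in place of ethyl on an oxygen next to a carbonyl group, which turns ethoxycarbonyl into carboxy. This oxygen is therefore a second place on the shared core where a single change moves the read-out beyond the scatter, alongside the aromatic carbon of the step of a number 13 percentage points higher from compound 1 to compound 2 (beyond the scatter). Here the number rises when the ethyl leaves and no new carbon group enters, but no measurement that bears on the reason for this rise is at hand.

The compounds shown do not tell whether the rise follows from losing the ethyl or from having the free carboxy, a question that a methyl or a longer chain on this oxygen, or an amide in place of the ethoxycarbonyl, would bear on. As far as these compounds go, it also remains open whether phenyl in place of methyl and hydrogen in place of ethyl add up when both are present on the shared core.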